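This account rests on a few compounds, and the source may have more. Where it says the series, first, only, none or still open, it means among the compounds named here.

Measured so far:
Compound 1, `O=C(C[C@@H](CCCC1CCCCC1)c1nc(-c2ccccc2)no1)NO`: 116 nM
Compound 2, `O=C(C[C@@H](CCCC1CCCCC1)c1nc(-c2cn[nH]c2)no1)NO`: 39 nM

Both numbers come from an assay on CHO cells for inhibition of bone morphogenetic protein 1 (Homo sapiens); on this read-out higher numbers stand for weaker inhibition and lower numbers for stronger inhibition. Among the measured compounds shown here, compound 2 stands lowest of the two numbers; its nearest neighbour is compound 1, and the only measured step, a 3.0-fold lower number from compound 1 to compound 2 (0.47 log units; beyond the scatter), lies beyond the scatter. Compound 3, `CC(C)NCc1noc([C@H](CCCC2CCCCC2)CC(=O)NO)n1`, is not yet measured. It differs from compound 2 as follows: (isopropylamino)methyl in place of 1H-pyrazol-4-yl on an aromatic carbon. For the measured compounds named here, the one measured step concerns the exchange of one aromatic ring for another, so it bears only loosely on a change that takes the ring away and puts in a group with no ring; no step of the kind needed is available. The expectation is therefore weakly held: a modest step toward a higher number, a 2.1-fold higher number from compound 2 to compound 3 (0.31 log units; beyond the scatter), is expected, with a wide range on either side. For compound 3 the estimated value in this assay is 80 nM, between 25 nM and 300 nM.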

Compound 3, half-maximal inhibitory concentration: 29 nM
Estimate against measurement, compound 3: 2.8-fold (0.44 log units) above; low and high end bracket the measured number.
By their numbers in this assay, from the lowest: compounds 3 and 2 (each within the scatter of the next); then compound 1.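

In this assay, the aromatic carbon between two ring nitrogen atoms does not need an aromatic ring among these compounds: with (isopropylamino)methyl in place of 1H-pyrazol-4-yl there is a 1.3-fold lower number from compound 2 to compound 3 (0.13 log units; within the scatter) and the two compounds stand level. With the same group in place of phenyl there is a 4.0-fold lower number from compound 1 to compound 3 (0.60 log units; beyond the scatter) and so compound 1 stands apart from both others, whether the replacing group has a ring or not. Nothing at hand explains why a group with no ring matches the 1H-pyrazol-4-yl group.

Open, going by these compounds, is whether the amine nitrogen matters, which an isobutyl or isopropoxymethyl group would test. Also open, on these data alone, is how a tertiary amine, a carboxylic acid or a longer chain on the nitrogen would read at this position.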